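Geometry switch at the exocyclic double bond of compound 1

The source may hold more compounds than are shown below. What is called first, only, known or untested is meant among the compounds shown, and "the series" means these compounds.

For the measured compounds named here, compound 1, `CCN(CC)CCCn1c(=O)/c(=C/c2ccc(F)cc2F)s/c1=C1\C(=O)Nc2cc(F)ccc21`, is the stronger of the two measured members. In a functional assay on K562 cells (Homo sapiens) for cytotoxicity, read by sulforhodamine B assay, with a stated time of 48 h (on this read-out lower numbers stand for stronger inhibition and higher numbers for weaker inhibition), compound 1 gives 3690 nM, the lowest number of the pair. Compound 2, `CCN(CC)CCCn1c(=O)/c(=C/c2ccc(F)c(F)c2)s/c1=C1/C(=O)Nc2ccc(F)cc21`, carries its fluorine atoms in different places on both rings; in this assay compound 2 gives 13400 nM, a higher number than compound 1 and a gap that lies beyond the usual scatter. Going by the values given here, no single-change step between measured compounds exists, so the size of any one modification in this set is not known from data.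

Compound 3, `CCN(CC)CCCn1c(=O)/c(=C/c2ccc(F)cc2F)s/c1=C1/C(=O)Nc2cc(F)ccc21`, is the next compound to be measured. It differs from compound 1 as follows: the two compounds have the same atoms and bonds and differ only in configuration as drawn: 1 of 2 stereo elements differ; a double bond is drawn Z in compound 1 and E in compound 3. The shared core and both fluorinated rings are unchanged. Among the compounds with values here, with no comparable step measured, the direction of the change is open. Compound 3 is expected to give a number close to that of compound 1, within a 1.6-fold higher number from compound 1 to compound 3 (0.21 log units; within the scatter), with a weakening rather than a strengthening being the more likely outcome. For compound 3 the estimate in this assay is 6000 nM, with a range from 1500 nM to 25000 nM.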

Compound 3, half-maximal inhibitory concentration: 3690 nM
Beside the measured number, compound 3's estimate is 1.6-fold (0.21 log units) above it; the range from low to high includes it.
By their numbers in this assay, from the lowest: compounds 1 and 3 (each within the scatter of the next); then compound 2.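

Notes on the series: in this assay, inverting the drawn geometry of this double bond gives no change at the digits printed from compound 1 to compound 3 (within the scatter). For the compounds shown here, this is the first single-change step in the set, and it gives the read-out at this position a measured reference: the Z and E drawings cannot be told apart in this assay. The comparison can be assigned to this one stereo element alone, because nothing else in the two structures changes: the fact that compounds 1 and 3 differ only in the configuration as drawn.

Still open, as far as these compounds go, is how the read-out responds when the diethylamine on the side chain gives way to a morpholine or a carboxylic acid, or when that chain is made longer. Also open, from the compounds shown here alone, are the effect of the second double bond's configuration, the effect of moving a single fluorine on either ring, and whether each drawn geometry persists in the assay medium over the stated time.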